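The source may hold more compounds than are shown below. What is called first, only, known or untested is meant among the compounds shown, and "the series" means these compounds.

Compounds measured in a functional assay on K562 cells (Homo sapiens) for inhibition, read by MTT assay, with a stated time of 48 h; on this read-out lower numbers stand for stronger inhibition and higher numbers for weaker inhibition:
- compound 1 `CCCCCNc1cc(C)n(Cc2ccccc2)c(=O)c1`: 140000 nM
- compound 2 `CCCCCn1c(C)cc(NCc2ccc(Cl)cc2)cc1=O`: > 300000 nM (a limit, not a number)
- compound 3 `Cc1cc(NCc2ccc(Cl)cc2)cc(=O)n1CCC(C)C`: 224000 nM

Compound 2 gives only a limit in this assay, namely > 300000 nM. That places it at the limit of > 300000 nM in this assay, at which 1 of the 3 values shown sits.

The change leading to compound 4 `CCCCCn1c(C)cc(NCc2ccccc2)cc1=O` puts hydrogen in place of chloro on an aromatic carbon. Cut one bond further out, this is 4-chlorophenyl to phenyl.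

Among the compounds with values here, no measured step makes this change, so the evidence is indirect. Within the data shown here, the one measured step, an at least 1.3-fold lower number from compound 2 to compound 3 (0.12 log units; that floor lies within the scatter), alters the chain and keeps the 4-chlorophenyl, and it does not separate the two compounds beyond the scatter. Compound 3 nevertheless gives a number with the 4-chlorophenyl in place, at 224000 nM. Compound 1 carries phenyl, with its substituents arranged differently on the core, and compound 1 gives 140000 nM.

Neither compound points to a firm step in this assay, so nothing beyond the scatter is expected, although a modestly lower number than the limit is the likelier direction. The expected change is an at least 1.2-fold lower number from compound 2 to compound 4 (0.09 log units; that floor lies within the scatter). For compound 4 the estimated value is 240000 nM, with an expected range from 120000 nM to 480000 nM.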

Compound 4, half-maximal inhibitory concentration: > 300000 nM
Compound 4: a limit, no number; the forecaster's own chance of this, stated with the estimate: 35%; middle value at least 1.2-fold (0.09 log units) from the limit.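

In this assay, compound 2 and compound 4 each give only a limit and not a number, so no step can be read between them: the limit of > 300000 nM in this assay, at which 2 of the 4 values shown sit.

The compounds shown leave open whether going from 4-chlorophenyl to phenyl on this shared core changes the read-out at all, and in which direction.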